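This account rests on a few compounds, and the source may have more. Where it says the series, first, only, none or still open, it means among the compounds named here.

Compound 1 `Cc1ccc(S(=O)(=O)N(CCn2cc(CCCF)nn2)[C@@H](C(=O)NO)C(C)C)cc1` and compound 2 `Cc1ccc(S(=O)(=O)N(CCn2cc(COCCOCCOCCOCCOCCF)nn2)[C@@H](C(=O)NO)C(C)C)cc1` differ in more than one place, and the difference between the two cores is not broken down here. In an assay on isolated protein for inhibition of matrix metalloproteinase-9 (Homo sapiens), read by fluorescence, with a stated time of 30 min (on this read-out higher numbers stand for weaker inhibition and lower numbers for stronger inhibition), compound 1 gives 3 nM, while compound 2 gives 0.4 nM, the lowest number among the three measured compounds. Compound 3 `CC(C)[C@H](C(=O)NO)N(CCn1cc(CCCF)nn1)S(=O)(=O)c1ccc(OCCF)cc1` carries the change 2-fluoroethoxy in place of methyl on an aromatic carbon on the core of compound 1; in this assay compound 3 gives 2 nM, so the step of a 1.5-fold lower number from compound 1 to compound 3 (0.18 log units; within the scatter). Compound 4 `CC(C)[C@H](C(=O)NO)N(CCn1cc(COCCOCCOCCOCCOCCF)nn1)S(=O)(=O)c1ccc(OCCF)cc1` applies the same change, (2-fluoroethoxy in place of methyl on an aromatic carbon), to the core of compound 2, at the same place. Because the step of a 1.5-fold lower number from compound 1 to compound 3 (0.18 log units; within the scatter) stayed within the scatter, the step of a 1.3-fold lower number from compound 2 to compound 4 (0.12 log units; within the scatter) is expected to be of similar size. Compound 4 is therefore estimated at 0.3 nM in this assay, with a likely range from 0.1 nM to 1 nM.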

Compound 4, half-maximal inhibitory concentration: 10 nM
The estimate for compound 4 lay 33-fold (1.52 log units) below the measured number; measured number outside the range, above it.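

In this assay, 2-fluoroethoxy in place of methyl gives a 25-fold higher number from compound 2 to compound 4 (1.40 log units; beyond the scatter). The effect of this change therefore did not carry from one core to the other, as the two steps clearly differ: the same change on two cores in this assay, a 1.5-fold lower number (0.18 log units; within the scatter) from compound 1 to compound 3 and a 25-fold higher number (1.40 log units; beyond the scatter) from compound 2 to compound 4, 38-fold (1.57 log units) apart, beyond the scatter of two such steps This shows that a step read on one core cannot simply be transferred to the other here, but it does not show what in the cores causes the difference, nor does one pair of cores set a rule for the series.

Going by these compounds, it remains open how a plain ethoxy or a methoxy group at the same place would behave on these two cores. On these data alone, it is also open whether a shorter ether chain on the core would give a step closer to the first or the second.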